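The source may report more compounds than this note shows. Statements on the series, on what has been measured and on what is new or still open speak of the compounds shown alone.

Of the compounds shown here, two built around a shared core have been tested in a functional assay on EKVX cells (Homo sapiens) for cytotoxicity, read by sulforhodamine B assay, with a stated time of 48 h, tested at 0.01 uM; a higher number here means a weaker effect of the compound at the concentration tested, a lower number a stronger effect. Compound 1, `COc1cc(C)cc(-c2c(-c3ccnc(-c4ccc(C(C)=O)cc4)c3)cnn2CC#N)c1`, carries a 4-acetylphenyl group; in this assay compound 1 gives 97%. Compound 2, `Cc1cc(O)cc(-c2nn(CC#N)cc2-c2ccnc(-c3ccc(N(C)C)cc3)c2)c1`, differs from compound 1 in more than one place and carries a 4-(dimethylamino)phenyl group; in this assay compound 2 gives 86%. Of the two numbers, compound 1 stands highest, and its gap to compound 2 lies beyond the usual scatter of repeated measurements, so compound 1 shows the weaker effect at this concentration.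

Compound 3, `COc1cc(C)cc(-c2c(-c3ccnc(-c4ccc(N(C)C)cc4)c3)cnn2CC#N)c1`, has not yet been measured. It is compound 1 with a single change: dimethylamino in place of acetyl on an aromatic carbon. Going by the values given here, no pair of measured compounds differs in exactly this one place, so the size of this step can only be expected, not read off. Because compound 2 gives 86% while carrying the same dimethylamino group, a modest downward step is expected, one that may not clearly exceed the scatter. The expected step is a number 7 percentage points lower from compound 1 to compound 3 (within the scatter). Compound 3 is estimated at 90%, within a range from 78% to 100%.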

Compound 3, a percentage reported as activity, at one concentration (the size of the read-out at that concentration, not a potency): 81%
Beside the measured number, compound 3's estimate is 9 percentage points above it; the measured number falls inside the stated range.
By their numbers in this assay, from the lowest: compounds 3 and 2 (each within the scatter of the next); then compound 1.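

In this assay, putting dimethylamino in place of acetyl on the aromatic carbon para to a large group gives a number 16 percentage points lower from compound 1 to compound 3 (beyond the scatter) and so shows that this position responds to the group it carries, although the step is modest. Compounds 1 and 2 could not show this on their own, as they differ in more than one place, whereas compound 1 and compound 3 differ only here. The two groups also match in the counts computed for them, each with 3 heavy atoms, 1 hydrogen-bond acceptor, no donor and no net charge, so those counts do not separate them, and no measurement shown here explains the difference between them.

With only acetyl and dimethylamino compared, these compounds cannot give a trend for this position, and one step says nothing about how other groups would behave. Going by these compounds, it remains open how a simple amine, a carboxylic acid or a longer chain on the same carbon would read in this assay, and whether any of them would move the number further than dimethylamino does.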